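This account rests on a few compounds, and the source may have more. Where it says the series, first, only, none or still open, it means among the compounds named here.

In a functional assay on A549 cells (Homo sapiens) for inhibition, tested at 100 uM (a lower number here means a weaker effect, a higher number a stronger effect of the compound at the concentration tested), three compounds have been measured: compound 1 `COc1ccc2c(-c3cc(C(F)(F)F)c(C#N)c(-c4cn(S(=O)(=O)c5ccc(C)cc5)c5cc(OC)ccc45)n3)cn(S(=O)(=O)c3ccc(C)cc3)c2c1` gives 21.2%; compound 2 `Cc1ccc(S(=O)(=O)n2cc(-c3cc(C(F)(F)F)ccn3)c3ccccc32)cc1` gives 30.5%; compound 3 `Cc1ccc(S(=O)(=O)n2cc(-c3cc(C(F)(F)F)cc(-c4cn(S(=O)(=O)c5ccc(C)cc5)c5ccccc45)n3)c3ccccc32)cc1` gives 69.3%.

Compound 1 thus has the lowest of the three numbers. Its nearest neighbour is compound 2, whose value lies within the usual scatter of it, so no order between the two can be claimed. Compound 3 stands far above compound 1, beyond the scatter. Compound 4 `COc1ccc2c(-c3cc(C(F)(F)F)cc(-c4cn(S(=O)(=O)c5ccc(C)cc5)c5cc(OC)ccc45)n3)cn(S(=O)(=O)c3ccc(C)cc3)c2c1` has not been measured. It differs from compound 1 in one place: hydrogen in place of cyano on an aromatic carbon. Going by the values given here, no measured pair shows this change on its own, so its effect has to be estimated. The step from compound 1 to compound 4 is expected to be upward, a number 23.8 percentage points higher from compound 1 to compound 4 (beyond the scatter), but of uncertain size. Compound 4 is therefore expected to give about 45%, within a range from 20% to 70%.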

Compound 4, a percentage reported as inhibition, at one concentration (the size of the read-out at that concentration, not a potency): 45.7%
For compound 4 the middle estimate is 0.7 percentage points below the measured one; low and high end bracket the measured number.
By their numbers in this assay, from the lowest: compounds 1 and 2 (each within the scatter of the next); then compound 4; then compound 3.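

In this assay, going by these compounds alone, putting hydrogen in place of cyano on this aromatic carbon, ortho to a trifluoromethyl group, gives a number 24.5 percentage points higher from compound 1 to compound 4 (beyond the scatter), the first direct reading of this position. On this core, then, the cyano group is not needed for a read-out of this size, and it goes with the lower number. Nothing at hand explains the step.

On these data alone, whether an amine, a carboxylic acid or a chlorine atom at this position would give a number nearer that of hydrogen or that of cyano stays open. So does whether the step holds on any other core.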